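Indoline for Tetrahydroisoquinoline on a Shared Aminopyrimidine Core

The source may report more compounds than this note shows. Statements on the series, on what has been measured and on what is new or still open speak of the compounds shown alone.

Measured compounds:
compound 1 `CN(c1ccc(Oc2ncnc3ccsc23)cc1)c1nccc(N2CCc3ccccc32)n1` with 38.2%
compound 2 `CN(c1ccc(Oc2ncnc3sccc23)cc1)c1nccc(N2CCc3ccccc3C2)n1` with 24.3%

Going by the values given here, in a functional assay on MDA-MB-231 cells (Homo sapiens) for inhibition, read by MTT assay, with a stated time of 72 h, tested at 20 uM (on this read-out higher numbers stand for more inhibition at the one concentration tested (going by the name of the read-out) and lower numbers for less inhibition), compound 2 gives 24.3%, the lower of the two numbers known. Its nearest neighbour is compound 1, which carries the 2,3-dihydro-1H-indol-1-yl group and gives 38.2% in this assay, a difference that lies beyond the scatter. Compound 3 `CN(c1ccc(Oc2ncnc3sccc23)cc1)c1nccc(N2CCc3ccccc32)n1` has not yet been measured. It differs from compound 2 in one place: 2,3-dihydro-1H-indol-1-yl in place of 1,2,3,4-tetrahydroisoquinolin-2-yl on an aromatic carbon. Among the compounds with values here, no step between measured compounds that differ in only this one place is available, so the expectation rests on the two values alone. Since compound 1, bearing the same 2,3-dihydro-1H-indol-1-yl group, gives 38.2%, the step of a number 10.7 percentage points higher from compound 2 to compound 3 (beyond the scatter) is expected to be upward and beyond the scatter. Compound 3 is therefore estimated at 35%, within a range from 20% to 50%.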

Compound 3, a percentage reported as inhibition, at one concentration (the size of the read-out at that concentration, not a potency): 17.7%
Beside the measured number, compound 3's estimate is 17.3 percentage points above it, outside the stated range (below it).
By their numbers in this assay, from the lowest: compounds 3 and 2 (each within the scatter of the next); then compound 1.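

In this assay, placing 2,3-dihydro-1H-indol-1-yl in place of 1,2,3,4-tetrahydroisoquinolin-2-yl on this aromatic carbon gives a number 6.6 percentage points lower from compound 2 to compound 3 (within the scatter), so this change does not separate the two compounds on this read-out. With 2,3-dihydro-1H-indol-1-yl held constant, exchanging the group on the oxygen on an aromatic ring gives a number 20.5 percentage points lower from compound 1 to compound 3 (beyond the scatter), which shows that the earlier gap between the two compounds of differing structure cannot be credited to the amine ring alone. Nothing available explains either step.

The compounds shown leave open whether a morpholine or a dimethylamino group on this aromatic carbon would give a different number in this assay. From the compounds shown here alone, with each compound read at only one concentration, their relative potency also remains open.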